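Compound 3 to compound 4: methyl in place of amino

This account rests on a few compounds, and the source may have more. Where it says the series, first, only, none or still open, it means among the compounds named here.

Of the compounds shown here, three have been tested in an ADME assay on MRC5 cells (Homo sapiens), read by MTT assay, with a stated time of 72 h; on this read-out higher numbers stand for weaker inhibition and lower numbers for stronger inhibition. Compound 1 `CN(C)c1ncnc2c1c(-c1cc3ccccc3o1)cn2[C@@H]1O[C@H](CO)[C@@H](O)[C@H]1O` reaches only a limit, > 100000 nM. Compound 2 `Nc1nc(N)c2c(-c3ccsc3)cn([C@@H]3O[C@H](CO)[C@@H](O)[C@H]3O)c2n1` also reaches only a limit, > 100000 nM. Within the data shown here, compound 3 `Nc1nc(N)c2c(-c3cc4ccccc4o3)cn([C@@H]3O[C@H](CO)[C@@H](O)[C@H]3O)c2n1` gives 78500 nM, the only actual number among the three, and it stands alongside (the limit of > 100000 nM in this assay, at which 2 of the 3 values shown sit).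

Compound 4 `Cc1nc(N)c2c(-c3cc4ccccc4o3)cn([C@@H]3O[C@H](CO)[C@@H](O)[C@H]3O)c2n1` differs from compound 3 by methyl in place of amino on an aromatic carbon, between two ring nitrogen atoms: methyl in place of amino on an aromatic carbon. Among the measured compounds shown here, the single measured step is 1-benzofuran-2-yl in place of thiophen-3-yl on an aromatic carbon, an at least 1.2-fold lower number from compound 2 to compound 3 (0.10 log units; that floor lies within the scatter). That step lies at another place on the molecule, and its floor stays within the scatter, so it offers only weak guidance. For the measured compounds named here, no measured step replaces this amino group, which leaves the new change untested in this assay.

Going by the values given here, with no measured step pointing to a real shift in either direction, no change beyond the scatter is expected, and a result reported only as a limit would be unsurprising. The expected change is a 1.1-fold higher number from compound 3 to compound 4 (0.03 log units; within the scatter). For compound 4 the estimated value is 85000 nM. The expected range for compound 4 runs from 40000 nM to 140000 nM.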

Compound 4, half-maximal inhibitory concentration: 91800 nM
Compound 4: the middle estimate sits 1.1-fold (0.03 log units) below what was measured, within the range that was stated.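

In this assay, the exchange on the aromatic carbon between two ring nitrogen atoms gives a 1.2-fold higher number from compound 3 to compound 4 (0.07 log units; within the scatter), so methyl in place of amino leaves the number within the usual scatter. Among these compounds, this is the first reading at this position, since the earlier step concerned a different aromatic carbon, and it shows that the amino group, with its hydrogen-bond donor and acceptor, can give way to methyl, which has neither, without a shift that can be read in this assay. Compound 3 and compound 4 therefore stand level, and they are the only compounds shown with actual numbers, while the other two values are limits: the limit of > 100000 nM in this assay, at which 2 of the 4 values shown sit.

The compounds shown leave open whether other groups on this carbon, such as a hydroxyl, a chlorine atom or a longer chain such as propyl, would also stay within the scatter or would move the number. They also leave open whether methyl in place of amino would read the same with thiophen-3-yl in place of 1-benzofuran-2-yl, or with a change to the amino group that remains on the ring.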